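Series notes: amine-end change on the propoxy chain

A few compounds are considered here, and "the series" means these few. Any claim that something is new, unique, unknown or untested is made for them only; others in the source may bear on it.

Compound 1 `COc1cc2c(Oc3ccc(NC(=O)c4cc(-c5ccccc5C)ccn4)cc3F)ccnc2cc1OCCCN1CCN(C)CC1` gives 240 nM in a functional assay on MKN-45 cells (Homo sapiens) for cytotoxicity, read by MTT assay, with a stated time of 72 h; a higher number here means a weaker inhibitor, a lower number a stronger inhibitor. Compound 2 `COc1cc2c(Oc3ccc(NC(=O)c4cc(-c5ccccc5F)ccn4)cc3F)ccnc2cc1OCCCN1CCN(C)CC1` gives 150 nM in this assay. Among the compounds with values here, the one measured step, a 1.6-fold lower number from compound 1 to compound 2 (0.20 log units; within the scatter), lies within the scatter, so the two numbers cannot be told apart and compound 1 stands together with compound 2 rather than apart from it.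

Compound 3 `COc1cc2c(Oc3ccc(NC(=O)c4cc(-c5ccccc5C)ccn4)cc3F)ccnc2cc1OCCCN1CCCC1` is not yet measured. It differs from compound 1 as follows: pyrrolidin-1-yl in place of 4-methylpiperazin-1-yl on a saturated chain carbon, three bonds along the chain from an oxygen on an aromatic ring. Within the data shown here, the only measured step concerns the substituent on the outer aromatic ring, far from the chain end, and it was within the scatter; no measured step touches the amine at the end of the propoxy chain. Nothing in the data therefore points to a change beyond the scatter in this assay, in either direction, and the range around the estimate is kept wide.

For compound 3 the expected step is a 1.0-fold higher number from compound 1 to compound 3 (0.02 log units; within the scatter). Compound 3 is accordingly estimated at 250 nM, with a range from 80 nM to 800 nM.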

Compound 3, half-maximal inhibitory concentration: 440 nM
Compound 3: middle estimate off by 1.8-fold (0.25 log units), on the low side, within the range that was stated.
By their numbers in this assay, from the lowest: compounds 2, 1 and 3 (each within the scatter of the next, the first and the last beyond it).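

The amine end of the propoxy chain now has its first measured step: in this assay, pyrrolidin-1-yl in place of 4-methylpiperazin-1-yl gives a 1.8-fold higher number from compound 1 to compound 3 (0.26 log units; within the scatter). This step lies within the scatter, so compound 1 and compound 3 cannot be told apart, even though the five-membered ring with one hetero atom replaces a six-membered ring with two and the change removes the methyl-bearing nitrogen of 4-methylpiperazin-1-yl. No measured information on the compounds accounts for this result or links it to any property of either amine.

Going by these compounds, whether this tolerance holds for other amine ends on the same chain remains open, for example morpholin-4-yl, piperidin-1-yl or dimethylamino, and a longer chain carrying pyrrolidin-1-yl could test whether the chain length matters. Also open, on these data alone, is whether pyrrolidin-1-yl reads the same when paired with the fluoro group of compound 2, since the amine-end step is so far known only with the methyl group of compound 1.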